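Flipping a single stereocentre in a fatty-acid amide hydrolase inhibitor

The source may hold more compounds than are shown below. What is called first, only, known or untested is meant among the compounds shown, and "the series" means these compounds.

Measured so far:
- compound 1, `O=C(c1ncc(-c2ccccn2)o1)C1CCc2cc(Oc3ccccc3)ccc2O1`: 70 nM; 50 nM (2 entries)
- compound 2, `O=C(c1ncc(-c2ccccn2)o1)[C@H]1COc2cc(Oc3ccccc3)ccc2C1`: 90 nM

Compound 1 has been tested more than once in an assay for inhibition of Fatty-acid amide hydrolase 1 (Mus musculus), with a stated time of 10 min (a higher number here means a weaker inhibitor, a lower number a stronger inhibitor), and its two entries agree well, as seen in the several entries of compound 1 in this assay, 70 nM; 50 nM (2 entries). Compound 2 has one number in this assay, plus a further entry that gives no single number; on that one number, compound 2 gives 90 nM, which sits close to the values of compound 1.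

Compound 3, `O=C(c1ncc(-c2ccccn2)o1)[C@@H]1COc2cc(Oc3ccccc3)ccc2C1`, has not yet been measured. It is built from compound 2 with no atoms added or removed: the two compounds have the same atoms and bonds and differ only in configuration as drawn: 1 of 1 stereo elements differ; a stereocentre at a saturated ring carbon is drawn R in compound 2 and S in compound 3. Since the two compounds share every atom and bond, the only thing the assay can respond to is which way this ring carbon is drawn. For the measured compounds named here, no measured step of this kind exists among the compounds here, so its size cannot be read off any pair. Changes of configuration at a single centre can leave potency nearly unchanged or shift it well beyond the scatter, in either direction.

Compound 3 is expected to give about 200 nM in this assay, within a range of 20 nM to 2000 nM, an expected step of a 2.2-fold higher number from compound 2 to compound 3 (0.35 log units; beyond the scatter).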

Compound 3, half-maximal inhibitory concentration: 460 nM
The estimate for compound 3 lay 2.3-fold (0.36 log units) below the measured number; low and high end bracket the measured number.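

In this assay, turning this one saturated ring carbon from the R to the S drawing gives a 5.1-fold higher number from compound 2 to compound 3 (0.71 log units; beyond the scatter), so the assay clearly responds to the direction of this centre, and within this pair the R drawing is the stronger inhibitor. The step can be assigned to that centre alone, because nothing else separates the two compounds: the fact that compounds 2 and 3 differ only in the configuration as drawn. Although modest, the step is larger than the spread between repeated entries for a single compound in this assay: the several entries of compound 1 in this assay, 70 nM; 50 nM (2 entries).

Compound 1 has no configuration drawn at its ring carbon, so the compounds shown do not reveal how its two mirror-image forms would compare with each other. For the compounds shown here, they also leave open whether the R drawing would still give the stronger inhibitor if an amine or a carboxylic acid were attached to the shared core, since this single pair shows the effect of the centre with only one set of surrounding groups.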